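Methyl on the phenylsulfonyl ring of compound 2

A few compounds are considered here, and "the series" means these few. Any claim that something is new, unique, unknown or untested is made for them only; others in the source may bear on it.

In a functional assay on SMMC-7721 cells (Homo sapiens) for cytotoxicity, read by MTT assay, with a stated time of 24 h (on this read-out higher numbers stand for weaker inhibition and lower numbers for stronger inhibition), compound 1 (`O=C1/C(=C/c2cccnc2)CNC/C1=C\c1ccccc1F`) gives > 20000 nM, which is a limit and not a number. Within the data shown here, compound 2 (`O=C1/C(=C/c2cccnc2)CN(S(=O)(=O)c2ccccc2)C/C1=C\c1ccccc1F`) gives 19100 nM, the only true number so far. Of the two readings, one is censored: the limit of > 20000 nM in this assay, at which 1 of the 2 values shown sits.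

The next member is compound 3 (`Cc1ccc(S(=O)(=O)N2C/C(=C\c3cccnc3)C(=O)/C(=C/c3ccccc3F)C2)cc1`), which takes compound 2 from phenylsulfonyl to (4-methylphenyl)sulfonyl, with methyl in place of hydrogen on an aromatic carbon, para to a large group: methyl in place of hydrogen on an aromatic carbon.

Among the measured compounds shown here, no measured step covers a change on this aromatic ring, so the evidence is indirect. The nearest step adds the phenylsulfonyl group itself. For the measured compounds named here, no step beyond the scatter is expected in this assay, and no direction is favoured, because an at least 1.0-fold lower number from compound 1 to compound 2 (0.01 log units; that floor lies within the scatter) is the only measured step. A report of compound 3 only as a limit would also fit this picture.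

The expected step is a 1.3-fold lower number from compound 2 to compound 3 (0.10 log units; within the scatter). For compound 3 the estimate is 15000 nM, with an expected range of 6000 nM to 30000 nM.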

Compound 3, half-maximal inhibitory concentration: 10300 nM
The estimate for compound 3 lay 1.5-fold (0.16 log units) above the measured number; the measured number falls inside the stated range.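

Methyl in place of hydrogen on this aromatic carbon, para to a large group, is the first change on the phenylsulfonyl ring with a measured outcome, and in this assay it gives a 1.9-fold lower number from compound 2 to compound 3 (0.27 log units; within the scatter), so compound 2 and compound 3 cannot be told apart at this position. Compared with the hydrogen on the amine nitrogen in a ring, the (4-methylphenyl)sulfonyl group gives an at least 1.9-fold lower number from compound 1 to compound 3 (0.28 log units; that floor lies within the scatter), and the series now holds two true numbers rather than one. That step remains a floor and its full size cannot be read, because compound 1 is reported only as a limit: the limit of > 20000 nM in this assay, at which 1 of the 3 values shown sits.

The compounds shown leave open whether another group on this aromatic carbon, such as methoxy, chlorine or a carboxylic acid, would give a step beyond the scatter, and whether methyl behaves the same way elsewhere on the ring. They also leave open what an acetyl group in place of the sulfonyl group on the amine nitrogen would do to the reading on the shared core.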